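The source may report more compounds than this note shows. Statements on the series, on what has been measured and on what is new or still open speak of the compounds shown alone.

Notes on the series. Compound 1 `CC(C)[C@H](NC(=O)COc1cccc2ccccc12)C(=O)N[C@@H](CC(=O)O)C(=O)COc1ccccc1` in a functional assay on Jurkat cells (Homo sapiens) (a higher number here means a weaker inhibitor, a lower number a stronger inhibitor), gives 14000 nM. Compound 2 `CC(C)[C@H](NC(=O)COc1cccc2ccccc12)C(=O)N[C@@H](CC(=O)O)C(=O)COc1cccc(F)c1` carries fluoro in place of hydrogen on an aromatic carbon. In this assay compound 2 reaches only a limit of the assay, > 100000 nM, and no number (the limit of > 100000 nM in this assay, at which 1 of the 2 values shown sits). The measured step is thus an at least 7.1-fold higher number from compound 1 to compound 2 (0.85 log units; beyond the scatter), known only as a bound. Compound 2 stands at the weak end of the two values shown, without a fixed figure.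

Compound 3 `CC(C)[C@H](NC(=O)COc1cccc2ccccc12)C(=O)N[C@@H](CC(=O)O)C(=O)COc1c(Cl)cccc1Cl` differs from compound 2 by 2,6-dichlorophenyl in place of 3-fluorophenyl on an oxygen on a saturated carbon. Among the compounds with values here, no measured step covers this exchange; the one step measured concerns a single fluoro entering, and compound 2 sits at the limit, so a change in compound 3 would show only as a clear recovery. None is expected on the evidence given. The step of a number no higher from compound 2 to compound 3 (the limit leaves the size open) is expected to stay within the scatter. Compound 3 in this assay is estimated at 100000 nM, with a range from 20000 nM to 500000 nM.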

Compound 3, half-maximal inhibitory concentration: 3000 nM
The estimate for compound 3 lay 33-fold (1.52 log units) above the measured number; the whole stated range lies above it.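

The ring on this oxygen on a saturated carbon does not respond to substitution in one direction only: with 2,6-dichlorophenyl in place of phenyl, this assay shows a 4.7-fold lower number from compound 1 to compound 3 (0.67 log units; beyond the scatter), so a substituted ring can also give a stronger inhibitor than phenyl. The loss seen with 3-fluorophenyl therefore does not extend to every substituted phenyl here, and compound 3 goes against any such reading. With 2,6-dichlorophenyl in place of 3-fluorophenyl, the record is an at least 33-fold lower number from compound 2 to compound 3 (1.52 log units; beyond the scatter), a step known only as a bound because compound 2 stands at a limit: the limit of > 100000 nM in this assay, at which 1 of the 3 values shown sits.

This exchange changes both the halogen and its place on the ring, and the compounds shown do not separate the two. A phenyl with one chlorine, a phenyl with two fluorines or a methoxy group on the ring would bear on that question.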